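The source may report more compounds than this note shows. Statements on the series, on what has been measured and on what is new or still open speak of the compounds shown alone.

Three compounds have been measured so far in a functional assay on HeLa cells (Homo sapiens) for antiproliferative activity, read by MTT assay, with a stated time of 72 h; a lower number here means a stronger inhibitor, a higher number a weaker inhibitor:

compound 1 `O=C1O[C@H]([C@@H](O)Cn2cc(-c3cccc(O)c3)nn2)C(OCc2ccccc2)=C1OCc1ccccc1` gives 39300 nM
compound 2 `CC(C)(C)c1cn(C[C@H](O)[C@H]2OC(=O)C(OCc3ccccc3)=C2OCc2ccccc2)nn1` gives 18300 nM
compound 3 `Cc1ccc(-c2cn(C[C@H](O)[C@H]3OC(=O)C(OCc4ccccc4)=C3OCc3ccccc3)nn2)cc1` gives 25500 nM

Compound 3 cannot be ranked against either of the other two. The numbers show a 1.5-fold lower number from compound 1 to compound 3 (0.19 log units; within the scatter) and a 1.4-fold higher number from compound 2 to compound 3 (0.14 log units; within the scatter), so it sits within the scatter of both.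

Compound 4 `O=C1O[C@H]([C@@H](O)Cn2cc(CCO)nn2)C(OCc2ccccc2)=C1OCc1ccccc1` has not yet been measured. It keeps the shared core and carries 2-hydroxyethyl in place of 4-methylphenyl on an aromatic carbon.

All three measured steps exchange the group at this same place. Only one passes the scatter, a 2.1-fold lower number from compound 1 to compound 2 (0.33 log units; beyond the scatter), and it is modest. Swaps here have therefore moved the number very little so far. Like compound 1 (39300 nM), compound 4 has a group bearing a hydroxyl, which points toward a number near that value. Among the measured compounds shown here, no measured compound carries 2-hydroxyethyl, so this remains a loose guide.

The expected step is a 1.6-fold higher number from compound 3 to compound 4 (0.20 log units; within the scatter), small and toward a higher number. For compound 4 the estimated value is 40000 nM, with an expected range from 17000 nM to 90000 nM.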

Compound 4, half-maximal inhibitory concentration: 68800 nM
Beside the measured number, compound 4's estimate is 1.7-fold (0.24 log units) below it; the range from low to high includes it.
By their numbers in this assay, from the lowest: compounds 2, 3, 1 and 4 (each within the scatter of the next, the first and the last beyond it).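

In this assay, 2-hydroxyethyl separates from the two groups that carry no hydroxyl, with a 2.7-fold higher number from compound 3 to compound 4 (0.43 log units; beyond the scatter) and a 3.8-fold higher number from compound 2 to compound 4 (0.58 log units; beyond the scatter), both modest, whereas a 1.8-fold higher number from compound 1 to compound 4 (0.24 log units; within the scatter) leaves it unresolved from 3-hydroxyphenyl. The two compounds with a hydroxyl-bearing group, compound 1 and compound 4, therefore both lean toward weaker inhibition, but compound 1 goes against a clean split, as it remains within the scatter of compound 3. Losing the aromatic ring does not by itself account for the shift: the tert-butyl group of compound 2 also has no ring, and compound 2 gives 18300 nM, so a group without a ring can sit at either end of this small set.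

No supporting data are available to explain why these numbers differ. A plain ethyl group would help separate the effect of the hydroxyl from that of chain size, while a longer chain ending in hydroxyl, an amine or a carboxylic acid would show how far this position responds to the end of the chain.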